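Isopropoxy to cyclopropylmethoxy on a shared core

A few compounds are considered here, and "the series" means these few. Any claim that something is new, unique, unknown or untested is made for them only; others in the source may bear on it.

Compound 1 `CCOC(=O)c1cnc(-c2ccccc2[N+](=O)[O-])[nH]c1=O` - "not determined" (no result reported)
Compound 2 `CCOC(=O)c1cnc(-c2ccccc2OC(C)C)[nH]c1=O` - 2 mg/kg

The measure here is a functional assay on the whole organism (strain Sprague-Dawley) for inhibition, with Rattus norvegicus as the target, with a stated time of 10 min; a lower number here means that less compound is needed, a higher number that more compound is needed for the effect. Among the measured compounds shown here, in it, compound 2 gives the only number so far (2 mg/kg). Compound 1 has no result ("not determined" (no result reported)), which leaves compound 2 with nothing to be ranked against.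

Compound 3 `CCOC(=O)c1cnc(-c2ccccc2OCC2CC2)[nH]c1=O` keeps the shared core and changes one group: cyclopropylmethyl in place of isopropyl on an oxygen on an aromatic ring. For the measured compounds named here, no measured pair shows what such a swap does. With compound 2 (2 mg/kg) as the only anchor, no step beyond the scatter is expected in this assay and no direction is favoured. The estimated step of no change at the digits printed from compound 2 to compound 3 (within the scatter) is expected to stay small. The estimate for compound 3 is 2 mg/kg (expected range 0.7 mg/kg to 6 mg/kg).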

Compound 3, dose for 50% inhibition: 0.3 mg/kg
The estimate for compound 3 lay 6.7-fold (0.82 log units) above the measured number, outside the stated range (below it).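

Replacing isopropyl with cyclopropylmethyl on this oxygen gives a 6.7-fold lower number from compound 2 to compound 3 (0.82 log units; beyond the scatter) in this assay, so less compound is needed for the effect. Among the compounds shown here, this is the first comparison the series allows, and it shows that the group on this oxygen on an aromatic ring can change the result. Neither group carries a hydrogen-bond donor or acceptor or a net charge, so a swap between two all-carbon groups is enough to move the number beyond the usual scatter. Nothing measured here explains the difference.

The compounds shown leave open whether the three-membered ring itself matters or whether an open butyl chain on the same oxygen would do the same. On these data alone, how an amine or a carboxylic acid at the end of this group would behave also remains open.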